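Benzyl ether variation on the shared core

The source may report more compounds than this note shows. Statements on the series, on what has been measured and on what is new or still open speak of the compounds shown alone.

In an assay on CHO cells for binding affinity to metabotropic glutamate receptor 2 (Rattus norvegicus) (a lower number here means a stronger inhibitor, a higher number a weaker inhibitor), compound 1 `N#Cc1cccc(CO[C@@H]2C[C@@H]3[C@H]([C@]2(N)C(=O)O)[C@@]3(F)C(=O)O)c1` gives 2.94 nM, the lowest number among the three measured. Compound 2 `N[C@]1(C(=O)O)[C@H]2[C@@H](C[C@H]1OCc1cccc(-c3ccccc3)c1)[C@]2(F)C(=O)O` gives 9.34 nM, and compound 3 `N[C@]1(C(=O)O)[C@H]2[C@@H](C[C@H]1OCc1cccc(Oc3ccccc3)c1)[C@]2(F)C(=O)O` gives 7.15 nM. The step of a 3.2-fold higher number from compound 1 to compound 2 (0.50 log units; beyond the scatter) and the step of a 2.4-fold higher number from compound 1 to compound 3 (0.39 log units; beyond the scatter) are both modest rises, while the step of a 1.3-fold lower number from compound 2 to compound 3 (0.12 log units; within the scatter) stays within scatter. Compound 4 `N[C@]1(C(=O)O)[C@H]2[C@@H](C[C@H]1OCc1cc(Cl)cc(Cl)c1)[C@]2(F)C(=O)O` differs from compound 1 by 3,5-dichlorophenyl in place of 3-cyanophenyl on a saturated chain carbon bound to an oxygen on a saturated carbon. Within the data shown here, no measured step exchanges the nitrile for chlorines, so the only guide is that both measured replacements of the nitrile on this ring raised the number modestly. For compound 4 a modest rise is therefore expected, a 2.0-fold higher number from compound 1 to compound 4 (0.31 log units; beyond the scatter). The estimate for compound 4 in this assay is 6 nM, expected within 2 nM to 18 nM.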

Compound 4, inhibition constant: 5.61 nM
Compound 4: middle estimate off by 1.1-fold (0.03 log units), on the high side; the measured number falls inside the stated range.
By their numbers in this assay, from the lowest: compounds 1, 4, 3 and 2 (each within the scatter of the next, the first and the last beyond it).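

In this assay, 3,5-dichlorophenyl in place of 3-cyanophenyl on this benzyl ether gives a 1.9-fold higher number from compound 1 to compound 4 (0.28 log units; within the scatter). Unlike the phenyl and phenoxy replacements of the nitrile, this change gives no step beyond the scatter, so a number level with compound 1 does not depend on the nitrile at this position. No supporting data bear on this result. Going by these compounds, it remains open whether a single chlorine would be enough, or how an amine or a carboxylic acid on the same aromatic ring would read in this assay.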